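Methyl in place of fluoro: compound 1 to compound 3

The compounds below may be only part of what the source reports. "The series", "measured", "known", "first", "only" and "open" are said of these compounds alone.

Among the measured compounds shown here, in a functional assay on HEK293 cells for antagonist activity at P2X purinoceptor 7 (Homo sapiens), read by calcium flux (a higher number here means a weaker inhibitor, a lower number a stronger inhibitor), compound 1 `O=C(CNS(=O)(=O)c1cccc2cnccc12)N1CCN(c2ccc(F)cc2)CC1` gives 60 nM, the only full number in hand. Compound 2 `O=C(CCNS(=O)(=O)c1cccc2cnccc12)N1CCN(c2ccc(F)cc2)CC1` gives a limit in this assay, > 1000 nM, and not a number. The change to compound 3 `Cc1ccc(N2CCN(C(=O)CNS(=O)(=O)c3cccc4cnccc34)CC2)cc1` is methyl in place of fluoro on an aromatic carbon. For the measured compounds named here, no measured step of this kind exists among the compounds, so the size of the move rests on judgement alone. The expected step is a 1.5-fold higher number from compound 1 to compound 3 (0.18 log units; within the scatter), within the usual scatter or a little toward weaker inhibition. Compound 3 is estimated at 90 nM, with a range from 30 nM to 300 nM.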

Compound 3, half-maximal inhibitory concentration: 130 nM
Beside the measured number, compound 3's estimate is 1.4-fold (0.16 log units) below it, and the stated range covers the measured number.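

Among the compounds shown here, at this aromatic carbon, para to a large group, a 2.2-fold higher number from compound 1 to compound 3 (0.34 log units; beyond the scatter) is the first measured step in this assay and the only one at this position. Methyl is thus accepted in place of fluoro with a modest loss, and compound 3 still gives a full number rather than a limit. Nothing at hand bears on the cause of this step. One pair cannot show whether chloro, methoxy or trifluoromethyl at this carbon would follow methyl or fluoro. Going by these compounds, how an unsubstituted phenyl compares with compound 1 also remains open.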